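This account rests on a few compounds, and the source may have more. Where it says the series, first, only, none or still open, it means among the compounds named here.

Measured compounds:
compound 1, `CC1=C(C(=O)Nc2ccc(Br)cc2)C(c2ccc(Cl)cc2Cl)N=C(SCc2cccc(Cl)c2)N1`, which in a functional assay on the whole organism (artery, strain albino) with Rattus norvegicus as the target, with a stated time of 900 min, at a dose of 10 mg/kg by the oral route (on this read-out lower numbers stand for less inhibition and higher numbers for more inhibition at the one dose given (going by the name of the read-out)), gives 7.2%;
compound 2, `CC1=C(C(=O)Nc2ccc(Br)cc2)C(c2ccc(Cl)cc2Cl)N=C(SCc2ccc(Cl)cc2)N1`, which in this assay gives 22.1%;
compound 3, `CC1=C(C(=O)Nc2ccc([N+](=O)[O-])cc2)C(c2cccc([N+](=O)[O-])c2)N=C(SCc2cccc(Cl)c2)N1`, which in this assay gives 10.8%.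

Compound 4, `CC1=C(C(=O)Nc2ccc([N+](=O)[O-])cc2)C(c2cccc([N+](=O)[O-])c2)N=C(SCc2ccc(Cl)cc2)N1`, has not been measured in this assay. Compound 2 differs from compound 1 by 4-chlorophenyl in place of 3-chlorophenyl on a saturated chain carbon bound to a sulfur, and this change produced a number 14.9 percentage points higher from compound 1 to compound 2 (beyond the scatter). The difference between the core of compound 1 and the core of compound 3 is not broken down here. Compound 4 differs from compound 3 by 4-chlorophenyl in place of 3-chlorophenyl on a saturated chain carbon bound to a sulfur, the same change at the same place. Within the data shown here, the step from compound 3 to compound 4 is therefore expected to be a number 11.2 percentage points higher from compound 3 to compound 4 (beyond the scatter), resting on a number 14.9 percentage points higher from compound 1 to compound 2 (beyond the scatter) as its only precedent. In this assay compound 4 is expected to give 22%, with a plausible range from 8% to 36%.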

Compound 4, a percentage reported as inhibition, in the whole organism at one dose (the size of the read-out at that dose, not a potency): 12.3%
Compound 4: middle estimate off by 9.7 percentage points, on the high side; the measured number falls inside the stated range.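

In this assay, replacing 3-chlorobenzyl with 4-chlorobenzyl on the sulfur of the nitro-substituted core gives a number 1.5 percentage points higher from compound 3 to compound 4 (within the scatter). Set beside the same change on the bromo-substituted core, the two steps cannot be told apart: the same change on two cores in this assay, a number 14.9 percentage points higher (beyond the scatter) from compound 1 to compound 2 and a number 1.5 percentage points higher (within the scatter) from compound 3 to compound 4, 13.4 percentage points apart, within the scatter of two such steps This shows no measurable dependence of the change on the core, but it does not show that the change carries over reliably, as only two pairs exist and only one of the two steps stands clear of the scatter.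

The compounds shown leave open how a 4-fluorobenzyl or a phenethyl group on the sulfur would read. They also leave open whether an amine on that phenyl ring would alter the picture.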